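Chloro step from compound 2 in the cytotoxicity read-out

This account rests on a few compounds, and the source may have more. Where it says the series, first, only, none or still open, it means among the compounds named here.

For the measured compounds named here, compound 1 `COc1ccc(C(C)=O)cc1S(=O)(=O)Nc1c(N)nc(SC)[nH]c1=O` and compound 2 `COc1ccc(C(=O)/C=C/c2ccccc2)cc1S(N)(=O)=O` are the two compounds read so far in an ADME assay on NIH3T3 cells (Mus musculus) for cytotoxicity, read by MTT assay, with a stated time of 48 h (on this read-out higher numbers stand for lower toxicity in this test and lower numbers for higher toxicity in this test), on these notes. Compound 1 sits at the limit > 1600000 nM and gives no actual number. Going by the values given here, compound 2 with 7700 nM holds the only actual number of the pair, so no ranking against a second number is possible yet.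

Compound 3 `COc1ccc(C(=O)/C=C/c2ccc(Cl)cc2)cc1S(N)(=O)=O` follows from compound 2 through chloro in place of hydrogen on an aromatic carbon with chloro in place of hydrogen on an aromatic carbon, para to a large group, phenyl to 4-chlorophenyl.

Among the compounds with values here, no measured step shows what such a change does, so the expectation rests on compound 2 at 7700 nM alone. A small move toward lower numbers, within the scatter, is expected, with a 1.4-fold lower number from compound 2 to compound 3 (0.15 log units; within the scatter) as the estimated step. The estimate for compound 3 is 5500 nM and the expected range runs from 1800 nM to 16000 nM for now.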

Compound 3, concentration lethal to 50% of the cells: 4100 nM
For compound 3 the middle estimate is 1.3-fold (0.13 log units) above the measured one; measured number inside the range.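

In this assay, for the compounds shown here, the only step with one change reads a 1.9-fold lower number from compound 2 to compound 3 (0.27 log units; within the scatter) and lies within the scatter, so this is the first direct reading at this position. Going from phenyl to 4-chlorophenyl leaves compound 2 and compound 3 indistinguishable on this test, which suggests that chloro in place of hydrogen on an aromatic carbon, para to a large group, is accepted here without a readable shift in the cytotoxicity read-out. Nothing in the measurements at hand bears on a cause for this step.

Chloro is the only replacement shown at this position. On these data alone, how fluoro, an amine or a carboxylic acid at the same place would read in this assay stays open, as does the reading of chloro elsewhere on that ring.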